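The compounds below may be only part of what the source reports. "The series", "measured", "known", "first", "only" and "open" are said of these compounds alone.

Compound 1, `CCCS(=O)(=O)c1ccc(C)c(C#Cc2cc(C#N)ccc2OCC(=O)O)c1`: 7 nM
Compound 2, `O=C(O)COc1ccc(Cl)cc1C#Cc1ccncc1`: 601 nM
Compound 3, `Cc1ccc(S(=O)(=O)N2CCCCC2C)cc1C#Cc1cc(Cl)ccc1OCC(=O)O`: 1.9 nM

Of the compounds shown here, three have been measured in an assay on CHO cells for displacement of a labelled ligand from prostaglandin D2 receptor 2 (Homo sapiens), read by scintillation counting; a higher number here means a weaker inhibitor, a lower number a stronger inhibitor. Compound 2 stands at the highest number of the three: compound 1, the nearest, gives 7 nM, and compound 3, the furthest, gives 1.9 nM, both gaps far beyond the scatter of repeated measurements. Compound 1 and compound 3 both carry a sulfonyl-bearing aryl group on the triple bond, whereas compound 2 carries a bare pyridine there.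

The piece follows the step from compound 2 to compound 4, `O=C(O)COc1ccc(Cl)cc1C#Cc1cccnc1`, which has not yet been measured in this assay. The two have the same atoms, joined differently: pyridin-3-yl in place of pyridin-4-yl on a triple-bonded carbon. For the measured compounds named here, no step between two measured compounds of this kind is available, so there is nothing among the three measured compounds that shows how moving the nitrogen within the pyridine ring changes the number.

With only that to go on, the step from compound 2 to compound 4 is expected to be small, probably within the scatter, and its direction cannot be read from the data: a 1.2-fold lower number from compound 2 to compound 4 (0.08 log units; within the scatter). Compound 4 is therefore estimated at 500 nM, with a range from 150 nM to 2000 nM.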

Compound 4, inhibition constant: 117 nM
Beside the measured number, compound 4's estimate is 4.3-fold (0.63 log units) above it, and the stated range ends above it.
By their numbers in this assay, from the lowest: compound 3; then compound 1; then compound 4; then compound 2.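

Moving the ring nitrogen is the only change among these compounds that can be read on its own: with pyridin-3-yl in place of pyridin-4-yl on a triple-bonded carbon, this assay shows a 5.1-fold lower number from compound 2 to compound 4 (0.71 log units; beyond the scatter). For the compounds shown here, this place on the compound therefore responds to where the nitrogen lies in the pyridine ring, although the two groups have the same heavy atoms and the same counts of hydrogen-bond donors and acceptors, something the earlier compounds, with no such pair among them, could not show. Nothing measured here accounts for the step.

As far as these compounds go, it remains open what pyridin-2-yl or a plain phenyl ring would give on the same triple-bonded carbon, and whether a methyl or methoxy group on the pyridin-3-yl ring would shift the number further. Compound 1 and compound 3 differ from compound 4 in more than one place, so the compounds shown also leave open whether the same nitrogen move would give a step of similar size with a nitrile or a sulfonyl-bearing aryl group present.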